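Replacing the styryl arm with a trimethoxyphenyl group

A few compounds are considered here, and "the series" means these few. Any claim that something is new, unique, unknown or untested is made for them only; others in the source may bear on it.

Two pyrazoline sulfonamides from this series have been measured for antiproliferative activity on A549 cells. Compound 1 `Cc1cc(O)c(C2=NN(c3ccc(S(N)(=O)=O)cc3)C(c3ccccc3O)C2)cc1Cl` gave 15500 nM in a functional assay on A549 cells (Homo sapiens) for antiproliferative activity, with a stated time of 48 h; on this read-out lower numbers stand for stronger inhibition of growth and higher numbers for weaker inhibition of growth. Among the measured compounds shown here, compound 2 `Cc1cc(O)c(C2=NN(c3ccc(S(N)(=O)=O)cc3)C(/C=C/c3ccccc3)C2)cc1Cl` gave 30800 nM in this assay, which is the higher of the two numbers, and the only step recorded, a 2.0-fold higher number from compound 1 to compound 2 (0.30 log units; within the scatter), lies within the usual scatter.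

Compound 3 `COc1ccc(C2CC(c3cc(Cl)c(C)cc3O)=NN2c2ccc(S(N)(=O)=O)cc2)c(OC)c1OC` has not yet been measured. It differs from compound 2 in one place: 2,3,4-trimethoxyphenyl in place of 2-phenylethenyl on a saturated ring carbon. For the measured compounds named here, the only measured step that bears on this position is the exchange of 2-hydroxyphenyl for 2-phenylethenyl between compound 1 and compound 2, which did not move the number beyond the scatter. Nothing measured here speaks to a trimethoxyphenyl group at this site, so no step beyond the scatter is expected, and the author leans only slightly toward a lower number, since an aromatic substituent at this carbon in compound 1 gave 15500 nM.

For compound 3 the expected step is a 1.7-fold lower number from compound 2 to compound 3 (0.23 log units; within the scatter), giving an estimated value of 18000 nM in this assay, with a range from 6000 nM to 60000 nM.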

Compound 3, concentration for total growth inhibition: 13800 nM
The estimate for compound 3 lay 1.3-fold (0.12 log units) above the measured number; measured number inside the range.
By their numbers in this assay, from the lowest: compounds 3, 1 and 2 (each within the scatter of the next, the first and the last beyond it).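

In this assay, among the compounds shown here, the step of a 2.2-fold lower number from compound 2 to compound 3 (0.35 log units; beyond the scatter) is the first change at this saturated ring carbon to go beyond the scatter, though it is only modest. The exchange removes the 2-phenylethenyl group, with its double bond outside aromatic rings, and brings in 2,3,4-trimethoxyphenyl, with 3 hydrogen-bond acceptors, but the step of a 1.1-fold lower number from compound 1 to compound 3 (0.05 log units; within the scatter) stays within the scatter, so the 2,3,4-trimethoxyphenyl and 2-hydroxyphenyl groups cannot be told apart at this site. Compound 2 is therefore separated only from compound 3 and not from compound 1, and nothing available accounts for that difference.

The compounds shown leave open whether all three methoxy groups are needed, or whether a single methoxy group or an unsubstituted phenyl ring at this carbon would give a number like that of compound 3. They also leave open how an amine or a carboxylic acid on this aromatic ring would read, and whether any group at this position can move the number by more than a modest step.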